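Changing the amide substituent: an expectation for compound 4

The source may report more compounds than this note shows. Statements on the series, on what has been measured and on what is new or still open speak of the compounds shown alone.

Going by the values given here, compound 2 `COc1ccc(/C=C/c2cc(OC)cc(OC)c2/C=C/C(=O)N2CCN(C)CC2)cc1` gives 4510 nM in a functional assay on A549 cells (Homo sapiens) for inhibition, read by MTT assay, with a stated time of 48 h (on this read-out lower numbers stand for stronger inhibition and higher numbers for weaker inhibition), the second highest of the three numbers known so far. Compound 1 `CCC(C)NC(=O)/C=C/c1c(/C=C/c2ccc(OC)cc2)cc(OC)cc1OC` gives 3950 nM and compound 3 `COc1ccc(/C=C/c2cc(OC)cc(OC)c2/C=C/C(=O)N2CCCC2)cc1` gives 6350 nM; the steps of a 1.1-fold higher number from compound 1 to compound 2 (0.06 log units; within the scatter) and a 1.4-fold higher number from compound 2 to compound 3 (0.15 log units; within the scatter) both stay within the scatter, as does a 1.6-fold higher number from compound 1 to compound 3 (0.21 log units; within the scatter). Compound 4 `COc1ccc(/C=C/c2cc(OC)cc(OC)c2/C=C/C(=O)NC(C)C)cc1` differs from compound 2 by isopropylamino in place of 4-methylpiperazin-1-yl on a carbonyl carbon. The step of a 1.1-fold higher number from compound 1 to compound 2 (0.06 log units; within the scatter), in which (sec-butyl)amino gave way to 4-methylpiperazin-1-yl, bears most on this change, and isopropylamino is the closer relative of (sec-butyl)amino. Since no change at the carbonyl carbon has moved the number beyond the scatter, compound 4 is expected to show a step of a 1.1-fold lower number from compound 2 to compound 4 (0.05 log units; within the scatter), with an estimate of 4000 nM and a range from 2000 nM to 8000 nM.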

Compound 4, half-maximal inhibitory concentration: 2360 nM
Compound 4: the middle estimate sits 1.7-fold (0.23 log units) above what was measured, within the range that was stated.
By their numbers in this assay, from the lowest: compounds 4, 1, 2 and 3 (each within the scatter of the next, the first and the last beyond it).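

In this assay the carbonyl carbon shows its first step beyond the scatter, though only a modest one, when isopropylamino replaces pyrrolidin-1-yl (a 2.7-fold lower number from compound 3 to compound 4 (0.43 log units; beyond the scatter)). The other two steps (a 1.9-fold lower number from compound 2 to compound 4 (0.28 log units; within the scatter); a 1.7-fold lower number from compound 1 to compound 4 (0.22 log units; within the scatter)) stay within the scatter, so compound 4 stands apart only from compound 3. Nothing given here accounts for this step. From the compounds shown here alone, whether a primary amide, a morpholin-4-yl amide or a longer chain on the amide nitrogen would move beyond the scatter from compound 4 remains open.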